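This account rests on a few compounds, and the source may have more. Where it says the series, first, only, none or still open, it means among the compounds named here.

Measured compounds:
Compound 1 `CC(C(=O)NCc1ccc(C(F)(F)F)nc1N1CCN(c2ccc(C(F)(F)F)cc2)CC1)c1ccc(NS(C)(=O)=O)c(F)c1`, in a functional assay on CHO-K1 cells for antagonist activity at transient receptor potential cation channel subfamily V member 1 (Homo sapiens), read by FLIPR (on this read-out higher numbers stand for weaker inhibition and lower numbers for stronger inhibition), compound 1 gives 2.3 nM.
Compound 2 `COc1ccc(N2CCN(c3nc(C(F)(F)F)ccc3CNC(=O)C(C)c3ccc(NS(C)(=O)=O)c(F)c3)CC2)cc1`, in this assay compound 2 gives 2.5 nM.

Compound 2 stands at the higher of the two numbers, though its neighbour compound 1 lies within the scatter. Compound 3 `CC(C(=O)NCc1ccc(C(F)(F)F)nc1N1CCN(Cc2ccccc2)CC1)c1ccc(NS(C)(=O)=O)c(F)c1` differs from compound 2 by benzyl in place of 4-methoxyphenyl on an amine nitrogen in a ring. Among the measured compounds shown here, the only measured step, a 1.1-fold higher number from compound 1 to compound 2 (0.04 log units; within the scatter), swaps one substituent on that aryl ring for another and stays within the scatter; it says little about replacing the aryl group by benzyl. For compound 3 a weaker result is expected, a 6.0-fold higher number from compound 2 to compound 3 (0.78 log units; beyond the scatter), with the estimate 15 nM spanning 3 nM to 80 nM.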

Compound 3, inhibition constant: 8.8 nM
For compound 3 the middle estimate is 1.7-fold (0.23 log units) above the measured one, within the range that was stated.
By their numbers in this assay, from the lowest: compounds 1 and 2 (each within the scatter of the next); then compound 3.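

Among the compounds shown here, on the amine nitrogen in the ring, benzyl in place of an aryl group gives the first change beyond the scatter in this assay: a 3.5-fold higher number from compound 2 to compound 3 (0.55 log units; beyond the scatter) and a 3.8-fold higher number from compound 1 to compound 3 (0.58 log units; beyond the scatter). The substituent swap on the aryl ring had moved nothing measurable, whereas this change is modest, and compound 3 still gives 8.8 nM. Nothing measured here accounts for the change. On these data alone, it stays open whether a plain phenyl, a 4-methoxybenzyl or a phenethyl group on that nitrogen would lie nearer compound 3 or nearer compound 1 and compound 2.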